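The compounds below may be only part of what the source reports. "The series", "measured", "known", "first", "only" and "open" are said of these compounds alone.

Among the measured compounds shown here, compound 3 `O=Cc1cc(=O)oc2cc(OCc3cccc(Cl)c3)ccc12` gives 52.5 nM in an assay on isolated protein (strain Sprague-Dawley) for inhibition of Amine oxidase [flavin-containing] B (Rattus norvegicus), read by spectrophotometry, with a stated time of 5 min (a higher number here means a weaker inhibitor, a lower number a stronger inhibitor), the highest of the two numbers so far; compound 2 `O=c1cc(CO)c2ccc(OCc3cccc(Cl)c3)cc2o1` gives 5.25 nM, and the step of a 10-fold higher number from compound 2 to compound 3 (1.00 log units; beyond the scatter) lies beyond the scatter. Compound 1 `NC(=O)COc1cc(=O)oc2cc(OCc3cccc(Cl)c3)ccc12` gives 3.1 nM; 3.31 nM (2 entries), and its repeated entries the several entries of compound 1 in this assay, 3.1 nM; 3.31 nM (2 entries) show how closely the assay reproduces. Compound 4 `CCOC(=O)c1cc(=O)oc2cc(OCc3cccc(Cl)c3)ccc12` differs from compound 3 by ethoxy in place of hydrogen on a carbonyl carbon. For the measured compounds named here, no measured step changes a carbonyl substituent in this way, so the earlier step is only a loose guide to how sensitive this position is. Compound 4 is therefore expected to move by a 2.6-fold lower number from compound 3 to compound 4 (0.42 log units; beyond the scatter), toward a lower number, with wide uncertainty. The estimate for compound 4 in this assay is 20 nM, between 4 nM and 100 nM.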

Compound 4, half-maximal inhibitory concentration: 417 nM
Beside the measured number, compound 4's estimate is 21-fold (1.32 log units) below it, and the stated range ends below it.
By their numbers in this assay, from the lowest: compound 2; then compound 3; then compound 4.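

Ethoxy in place of hydrogen on the carbonyl carbon brings a 7.9-fold higher number from compound 3 to compound 4 (0.90 log units; beyond the scatter) in this assay, so extending the formyl group to ethoxycarbonyl weakens inhibition further rather than strengthening it. Measured against hydroxymethyl, the change gives a 79-fold higher number from compound 2 to compound 4 (1.90 log units; beyond the scatter), a wider gap than the earlier 10-fold higher number from compound 2 to compound 3 (1.00 log units; beyond the scatter). These steps are far larger than the differences between repeated measurements: the several entries of compound 1 in this assay, 3.1 nM; 3.31 nM (2 entries)

Still open, going by these compounds, is how a carboxylic acid or an aminomethyl group would read at this place. On these data alone, a longer chain on the ester oxygen, such as butoxy, is equally open.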